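The source may report more compounds than this note shows. Statements on the series, on what has been measured and on what is new or still open speak of the compounds shown alone.

Of the compounds shown here, three built on one shared core have been measured in a functional assay on cells (Cancer cell lines, Homo sapiens) for inhibition; a lower number here means a stronger inhibitor of growth, a higher number a weaker inhibitor of growth. Compound 1 `N=C(N)N/N=C/c1c(-c2cccs2)nc2sccn12` gives 10200 nM in this assay. Compound 2 `N=C(N)N/N=C/c1c(-c2ccsc2)nc2sccn12` differs from it only by thiophen-3-yl in place of thiophen-2-yl on an aromatic carbon, and in this assay compound 2 gives 15500 nM; the step of a 1.5-fold higher number from compound 1 to compound 2 (0.18 log units; within the scatter) lies within the scatter. Compound 3 `Cc1cc(-c2nc3sc(C)cn3c2/C=N/NC(=N)N)c(C)s1` carries two methyl groups on its thiophene and one methyl on the fused core, and in this assay compound 3 gives 12000 nM. On the numbers shown, compound 3 stands with the second highest of the three, its gap to compound 1 and its gap to compound 2 each within the scatter, so none of the three can be told apart.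

Within the data shown here, compound 4 `Cc1cc(-c2nc3sccn3c2/C=N/NC(=N)N)c(C)s1` is the next case. hydrogen in place of methyl on an aromatic carbon No measured step removes a methyl from the fused core; the one measured step, a 1.5-fold higher number from compound 1 to compound 2 (0.18 log units; within the scatter), is within the scatter, and all three numbers sit close together. Compound 4 is therefore expected to show a step of no change at the digits printed from compound 3 to compound 4 (within the scatter). Compound 4 is expected to give about 12000 nM in this assay, within a range from 5000 nM to 28000 nM.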

Compound 4, concentration for 50% growth inhibition: 17400 nM
Compound 4: middle estimate off by 1.5-fold (0.16 log units), on the low side, and the stated range covers the measured number.
By their numbers in this assay, from the lowest: compounds 1, 3, 2 and 4 (each within the scatter of the next).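

In this assay, among these compounds, hydrogen in place of methyl on the aromatic carbon next to the ring sulfur, in the five-membered aromatic ring with 1 nitrogen and 1 sulfur, gives a 1.5-fold higher number from compound 3 to compound 4 (0.16 log units; within the scatter), so the methyl at this position can be removed with no step that stands out from the scatter. The two comparisons on the other substituent read the same way: 2,5-dimethylthiophen-3-yl in place of thiophen-3-yl gives a 1.1-fold higher number from compound 2 to compound 4 (0.05 log units; within the scatter), and 2,5-dimethylthiophen-3-yl in place of thiophen-2-yl gives a 1.7-fold higher number from compound 1 to compound 4 (0.23 log units; within the scatter), so neither the methyl on the core nor the thiophene variants shown separate these four compounds from one another. Nothing available explains why these steps are this small.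

What the compounds shown leave open is whether an amine, a carboxylic acid or a longer chain such as propyl on this same carbon would move the number in this assay beyond the scatter. As far as these compounds go, it is equally open whether a phenyl or a pyridine ring in place of the thiophene would produce a step that can be read at all.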